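Methoxycarbonyl replaces trifluoromethyl: what cytotoxicity to expect

The source may report more compounds than this note shows. Statements on the series, on what has been measured and on what is new or still open speak of the compounds shown alone.

The shared core appears first in compound 1 (`Cc1cc(CCC#N)cc(C)c1Oc1cc(Nc2ccc(C#N)cc2)c(N)cc1N`), which gives > 25000 nM in an ADME assay on TZM cells (Homo sapiens) for cytotoxicity, read by XTT assay, with a stated time of 4 days; on this read-out lower numbers stand for higher toxicity in this test and higher numbers for lower toxicity in this test. That value is a limit of the assay and not a number. Compound 2 (`Cc1cc(CCC#N)cc(C)c1Oc1cc(Nc2ccc(C#N)cc2)c(N)cc1C(F)(F)F`) gives > 7100 nM in this assay, and this too is only a limit. Compound 2 therefore has no exact position on the scale.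

Compound 3 (`COC(=O)c1cc(N)c(Nc2ccc(C#N)cc2)cc1Oc1c(C)cc(CCC#N)cc1C`) differs from compound 2 at a single place, where methoxycarbonyl stands in place of trifluoromethyl on an aromatic carbon: methoxycarbonyl in place of trifluoromethyl on an aromatic carbon.

Within the data shown here, only one measured step bears on this change: a step that the two limits leave unreadable from compound 1 to compound 2. Among the measured compounds shown here, it involves the same aromatic carbon, but it gives no size that could be carried over to the new change, and no measured step shows the effect of methoxycarbonyl. For the measured compounds named here, with only that unreadable step from compound 2 as a guide, no shift beyond the scatter is expected in this assay, and no direction can be argued with confidence.

The expected change is a step that the limit leaves unreadable from compound 2 to compound 3, an estimate that stays close to the limit of compound 2.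

For compound 3 the estimated value is 12000 nM, with an expected range from 5000 nM to 30000 nM.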

Compound 3, half-maximal cytotoxic concentration: > 22700 nM
Compound 3: no number, only a limit; the forecaster's own chance of this, stated with the estimate: 55%; middle value at least 1.8-fold (0.27 log units) away from the limit.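

In this assay compound 3 gives > 22700 nM, which is a limit of the assay and not a number. Among these compounds, compound 1 and compound 2 also stand only as limits, so no step among the three compounds can be read. The compounds shown leave open whether amino, trifluoromethyl or methoxycarbonyl on this aromatic carbon changes cytotoxicity at all.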